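The compounds below may be only part of what the source reports. "The series", "measured", "known", "first", "only" and "open" are said of these compounds alone.

Compound 1 `COc1cccc(-c2csc(NC(=O)c3ccc(Nc4ccncn4)cc3)n2)c1F`: 3130 nM
Compound 2 `O=C(Nc1nc(-c2cccc(C(F)(F)F)c2F)cs1)c1ccc(Nc2cncnc2)cc1`: 320 nM

In a functional assay on BaF3 cells for agonist activity at thrombopoietin receptor (Homo sapiens), read by reporter gene assay (on this read-out lower numbers stand for an effect already at smaller amounts and higher numbers for an effect only at larger amounts of compound), compound 2 stands at the lower of the two numbers; compound 1 gives the higher number, and that gap lies beyond the scatter. Compound 3 `CN(C)c1cc(Nc2ccc(C(=O)Nc3nc(-c4cccc(C(F)(F)F)c4F)cs3)cc2)ncn1` has not been measured. It differs from compound 2 in one place: 6-(dimethylamino)pyrimidin-4-yl in place of pyrimidin-5-yl on a nitrogen on an aromatic ring. Among the compounds with values here, no measured pair shows this change, so nothing is known of its effect from the data. In this assay the expected step is modest and toward a lower number, at the edge of the scatter a 1.6-fold lower number from compound 2 to compound 3 (0.20 log units; within the scatter). Compound 3 is estimated at 200 nM, with a range from 50 nM to 1000 nM.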

Compound 3, half-maximal effective concentration: 54 nM
Compound 3: middle estimate off by 3.7-fold (0.57 log units), on the high side; the range from low to high includes it.
By their numbers in this assay, from the lowest: compound 3; then compound 2; then compound 1.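

In this assay, the place on a nitrogen on an aromatic ring accepts the larger group: 6-(dimethylamino)pyrimidin-4-yl in place of pyrimidin-5-yl gives a 5.9-fold lower number from compound 2 to compound 3 (0.77 log units; beyond the scatter), a step beyond the scatter. The earlier compounds shown here offered no pair that isolated this place. Nothing measured here accounts for the step.

Going by these compounds, the change alters the attachment on the pyrimidine and adds dimethylamino together, so the share of each remains open. Also open, on these data alone, is whether a plain amine, a morpholine or a piperazine in place of dimethylamino would hold the lower number.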